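Extending the chain on the ring nitrogen of compound 1

This account rests on a few compounds, and the source may have more. Where it says the series, first, only, none or still open, it means among the compounds named here.

Measured compounds:
- compound 1, `CCCn1nc(-c2cccnc2)c2ccccc2c1=O`: 86%
- compound 2, `COCCn1nc(-c2cccnc2)c2ccccc2c1=O`: 55%
- compound 3, `O=c1c2ccccc2c(-c2cccnc2)nn1CCO`: 69%

In an assay on isolated protein (Oryctolagus cuniculus) with Thromboxane-A synthase (Homo sapiens) as the target, tested at 1 uM (on this read-out higher numbers stand for more inhibition at the one concentration tested (going by the name of the read-out) and lower numbers for less inhibition), compound 1 stands highest of the three measured; compound 3 comes nearest, and compound 2 sits furthest down. Both departures from compound 1 concern the chain on the aromatic nitrogen: a number 31 percentage points lower from compound 1 to compound 2 (beyond the scatter) with methoxy in place of methyl, and a number 17 percentage points lower from compound 1 to compound 3 (beyond the scatter) with hydroxy in place of methyl. Between the two altered chains, a number 14 percentage points higher from compound 2 to compound 3 (beyond the scatter).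

Compound 4, `CC(C)NC(=O)CCCn1nc(-c2cccnc2)c2ccccc2c1=O`, is not yet measured. It differs from compound 1 by isopropylcarbamoyl in place of hydrogen on a saturated chain carbon, three bonds along the chain from an aromatic nitrogen. The two measured steps that bear on it are those from compound 1 to compound 2 and from compound 1 to compound 3, both of which lowered this assay when the chain was altered, one by a large and one by a modest amount. The change to compound 4 is larger in heavy atoms than either and sits one bond further along the chain, so a drop is expected rather than a gain, though its size is uncertain.

The expected step is a number 24 percentage points lower from compound 1 to compound 4 (beyond the scatter). For compound 4 the estimate in this assay is 62%, with a range from 38% to 84%.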

Compound 4, a percentage reported as inhibition, at one concentration (the size of the read-out at that concentration, not a potency): 89%
Compound 4: the middle estimate sits 27 percentage points below what was measured, outside the stated range (above it).
By their numbers in this assay, from the lowest: compound 2; then compound 3; then compounds 1 and 4 (each within the scatter of the next).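

In this assay, the losses seen with methoxy and hydroxy do not extend to every change on this chain: isopropylcarbamoyl on a saturated chain carbon, three bonds along the chain from an aromatic nitrogen, brings in 6 heavy atoms and gives a number 3 percentage points higher from compound 1 to compound 4 (within the scatter). The chain of compound 4 also stands clear of both oxygen-bearing chains, with a number 20 percentage points higher from compound 3 to compound 4 (beyond the scatter) and a number 34 percentage points higher from compound 2 to compound 4 (beyond the scatter), so the size of the group entering at this position does not by itself set the direction of the step across these four compounds. Nothing available explains why these chains differ.

As far as these compounds go, it remains open whether the isopropylcarbamoyl group itself matters or whether any longer chain would serve as well; a plain butyl or pentyl chain, and chains ending in a carboxylic acid or an amine, would help separate the two. Compound 1 and compound 4 also remain unseparated at the one concentration tested, and whether the isopropyl group on the amide nitrogen contributes anything could be tested against a cyclopropyl or tert-butyl amide.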